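Fluoro for acetamido on the aryl ring of compound 3

A few compounds are considered here, and "the series" means these few. Any claim that something is new, unique, unknown or untested is made for them only; others in the source may bear on it.

Measured so far in a functional assay on M14 cells (Homo sapiens) for antiproliferative activity, with a stated time of 72 h; a higher number here means a weaker inhibitor, a lower number a stronger inhibitor:
compound 1, `C=CC[C@H]1C[C@]2([C@@H](C)Cc3ccc(OC)c(OC)c3)OCOC2=CC1=O`: 110 nM
compound 2, `C=CC[C@H]1C[C@]2([C@@H](C)Cc3ccc(OC)c(C#N)c3)OCOC2=CC1=O`: 180 nM
compound 3, `C=CC[C@H]1C[C@]2([C@@H](C)Cc3ccc(OC)c(NC(C)=O)c3)OCOC2=CC1=O`: 85 nM

All three compounds share one core and differ only in the group on the aromatic carbon ortho to the methoxy group. Among the measured compounds shown here, compound 3 gives the lowest number of the three in this assay, but the step of a 1.3-fold lower number from compound 1 to compound 3 (0.11 log units; within the scatter) is within the scatter, so compound 3 and compound 1 cannot be ordered; only the step of a 2.1-fold lower number from compound 2 to compound 3 (0.33 log units; beyond the scatter) is beyond the scatter, and it is modest. The step of a 1.6-fold higher number from compound 1 to compound 2 (0.21 log units; within the scatter) is likewise within the scatter.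

Compound 4, `C=CC[C@H]1C[C@]2([C@@H](C)Cc3ccc(OC)c(F)c3)OCOC2=CC1=O`, takes the change (fluoro in place of acetamido on an aromatic carbon), on the aromatic carbon ortho to a methoxy group and meta to a large group. For the measured compounds named here, no measured step exchanges acetamido for a single halogen, so the bearing steps are only indirect: three different groups at this position all land within a narrow band. Compound 4 is therefore expected to stay in that band, with the estimated step of a 1.5-fold higher number from compound 3 to compound 4 (0.18 log units; within the scatter) small. For compound 4 the estimated value in this assay is 130 nM, in the range 60 nM to 300 nM.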

Compound 4, half-maximal inhibitory concentration: 8 nM
Compound 4: the middle estimate sits 16-fold (1.21 log units) above what was measured; the whole stated range lies above it.
By their numbers in this assay, from the lowest: compound 4; then compounds 3, 1 and 2 (each within the scatter of the next, the first and the last beyond it).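

In this assay, among the compounds shown here, this position turns out to be far more sensitive than the earlier compounds suggested, as fluoro stands clear of all three other groups: there is an 11-fold lower number from compound 3 to compound 4 (1.03 log units; beyond the scatter) and a 14-fold lower number from compound 1 to compound 4 (1.14 log units; beyond the scatter) and also a 23-fold lower number from compound 2 to compound 4 (1.35 log units; beyond the scatter). The narrow band formed by methoxy, cyano and acetamido therefore does not describe the position as a whole, since the group on this aromatic carbon can move the number much further than those three showed. Compound 4 is the strongest of the four compounds shown, with each of its steps large and beyond the scatter.

Nothing available here accounts for the size of this change. Going by these compounds, it remains open whether this potency is particular to fluoro or is shared by chloro, bromo or an amine on the same aromatic carbon.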